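A few compounds are considered here, and "the series" means these few. Any claim that something is new, unique, unknown or untested is made for them only; others in the source may bear on it.

Measured in a functional assay on K562 cells (Homo sapiens) for antiproliferative activity, with a stated time of 72 h; a lower number here means a stronger inhibitor, a higher number a weaker inhibitor:
- Compound 1 `CCCC#Cc1cc([C@@H]2O[C@H](CO)[C@@H](O)[C@H]2O)n2ncnc(N)c12`: 1100 nM
- Compound 2 `Nc1ncnn2c([C@@H]3O[C@H](CO)[C@@H](O)[C@H]3O)cc(C#Cc3cccs3)c12`: > 100000 nM (a limit)
- Compound 3 `Nc1ncnn2c([C@@H]3O[C@H](CO)[C@@H](O)[C@H]3O)cc(-c3ccc(F)cc3F)c12`: 69700 nM

Compound 3, at 69700 nM, holds the higher of the two values that are not limits. Compound 4 `Cc1ccccc1-c1cc([C@@H]2O[C@H](CO)[C@@H](O)[C@H]2O)n2ncnc(N)c12` carries 2-methylphenyl in place of 2,4-difluorophenyl on an aromatic carbon.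

The large steps, an at least 90-fold higher number from compound 1 to compound 2 (1.95 log units; beyond the scatter) and a 63-fold higher number from compound 1 to compound 3 (1.80 log units; beyond the scatter), both start from the pent-1-yn-1-yl group, which compound 4 does not carry. Closer to this swap is an at least 1.4-fold lower number from compound 2 to compound 3 (0.15 log units; that floor lies within the scatter). Going by the values given here, no step between two phenyl groups has been measured, so no step beyond the scatter is expected in this assay. The expected step is a 1.4-fold lower number from compound 3 to compound 4 (0.14 log units; within the scatter). For compound 4 the estimated value is 50000 nM, with an expected range of 10000 nM to 100000 nM.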

Compound 4, half-maximal inhibitory concentration: > 100000 nM
Compound 4 ended at the assay's limit; the forecaster's own chance of this, stated with the estimate: 30%; middle value at least 2.0-fold (0.30 log units) from the limit.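

In this assay compound 4 gives > 100000 nM, which is a limit of the assay: the limit of > 100000 nM in this assay, at which 2 of the 4 values shown sit.

A second substituted phenyl group on this aromatic carbon also falls far short of pent-1-yn-1-yl, with an at least 90-fold higher number from compound 1 to compound 4 (1.95 log units; beyond the scatter). Between the two phenyl groups, the only reading is an at least 1.4-fold higher number from compound 3 to compound 4 (0.15 log units; that floor lies within the scatter), and the steps to compound 2 cannot be read.

Open, from the compounds shown here alone, is whether a longer alkyne chain or an amine on this carbon would keep or improve on compound 1 at 1100 nM.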